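From 3,4-dichlorophenyl to pyridin-3-yl on the amide

The compounds below may be only part of what the source reports. "The series", "measured", "known", "first", "only" and "open" are said of these compounds alone.

In an in vitro ADME assay on microsomes from liver (Homo sapiens) for pharmacokinetics, read by LC-MS, with a stated time of 10 min, tested at 1 uM (a higher number here means faster removal of the compound, a lower number slower removal), compound 1 (`CN1C[C@H](C(=O)Nc2cccc(F)c2)[C@@H](c2ccc(/C=C/C(=O)Nc3ccccc3N)cc2)C1`) gives 6 mL/min/kg and compound 2 (`CN1C[C@H](C(=O)Nc2cccc(Cl)c2)[C@@H](c2ccc(/C=C/C(=O)Nc3ccccc3N)cc2)C1`) gives 7 mL/min/kg as its reading, with a 1.2-fold higher number from compound 1 to compound 2 (0.07 log units; within the scatter) as the step between them. Compound 3 (`CN1C[C@H](C(=O)Nc2ccc(Cl)c(Cl)c2)[C@@H](c2ccc(/C=C/C(=O)Nc3ccccc3N)cc2)C1`), at 14 mL/min/kg, stands clear of compound 1 alone: the two steps into it are a 2.3-fold higher number from compound 1 to compound 3 (0.37 log units; beyond the scatter) and a 2.0-fold higher number from compound 2 to compound 3 (0.30 log units; within the scatter) in this short series.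

Compound 4 (`CN1C[C@H](C(=O)Nc2cccnc2)[C@@H](c2ccc(/C=C/C(=O)Nc3ccccc3N)cc2)C1`) has pyridin-3-yl in place of 3,4-dichlorophenyl on an amide-type nitrogen. For the measured compounds named here, no compound with that group has been measured, so the closest guide is the size of the step linking compound 1 to compound 3, taken in reverse. A modest fall is therefore expected, namely a 2.8-fold lower number from compound 3 to compound 4 (0.45 log units; beyond the scatter) as estimated here. For compound 4 the estimated clearance is 5 mL/min/kg, with an expected range of 2.5 mL/min/kg to 11 mL/min/kg in this assay.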

Compound 4, clearance: 10 mL/min/kg
The estimate for compound 4 lay 2.0-fold (0.30 log units) below the measured number, within the range that was stated.
By their numbers in this assay, from the lowest: compounds 1, 2, 4 and 3 (each within the scatter of the next, the first and the last beyond it).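

In this assay, pyridin-3-yl on the amide-type nitrogen stays within the scatter of all three phenyl-bearing compounds: a 1.4-fold lower number from compound 3 to compound 4 (0.15 log units; within the scatter), a 1.4-fold higher number from compound 2 to compound 4 (0.15 log units; within the scatter), and a 1.7-fold higher number from compound 1 to compound 4 (0.22 log units; within the scatter). A six-membered aromatic ring with a hetero atom therefore gives a reading not separable from those with 3-fluorophenyl, 3-chlorophenyl or 3,4-dichlorophenyl at this place. Nothing available explains this result.

Going by these compounds, whether pyridin-2-yl or pyridin-4-yl would read the same remains open. So does the outcome for a saturated ring such as piperidin-4-yl on this nitrogen.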